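A few compounds are considered here, and "the series" means these few. Any claim that something is new, unique, unknown or untested is made for them only; others in the source may bear on it.

Measured in a functional assay on K562 cells (Homo sapiens) for cytotoxicity; a lower number here means that less compound is tolerated, a higher number that more compound is tolerated:
- compound 1 `CC1=CC(=O)[C@@H]2[C@@]3(C)CCCC(C)(C)[C@@H]3[C@@H](O)C[C@]2(C)c2c1ccc(C)c2O`: 5400 nM
- compound 2 `C=C1/C=C\[C@@H]2[C@@]3(C)CCCC(C)(C)[C@@H]3[C@H](O)C[C@@]2(C)O[C@@H]2C=C(C)C(=O)C[C@H]12`: 4500 nM

In this assay, compound 1 gives 5400 nM and compound 2 gives 4500 nM. These two numbers lie within the usual scatter of each other, so compound 1 stands level with compound 2 and neither can be ranked.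

The next compound to consider is compound 3 `COc1c(C)ccc2c1[C@@]1(C)C[C@H](O)[C@H]3C(C)(C)CCC[C@]3(C)[C@H]1C(=O)C=C2C`. It keeps the core of compound 1 but has methyl in place of hydrogen on an oxygen on an aromatic ring, which turns hydroxy to methoxy (methyl in place of hydrogen on an oxygen on an aromatic ring).

Among the measured compounds shown here, the two measured compounds differ in more than one place, so no measured step shows what this single change does. With so small a change, no step beyond the scatter is expected in this assay. The estimated change is a 1.2-fold higher number from compound 1 to compound 3 (0.08 log units; within the scatter), which stays within the scatter. Compound 3 is expected at 6500 nM, with an estimated range from 2200 nM to 19000 nM.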

Compound 3, concentration lethal to 50% of the cells: > 100000 nM
Compound 3 ended at the assay's limit (the forecaster's own chance of this, stated with the estimate: 10%); middle value at least 15-fold (1.18 log units) away from the limit.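

Putting methyl on the oxygen on the aromatic ring, which turns hydroxy to methoxy, gives an at least 18-fold higher number from compound 1 to compound 3 (1.26 log units; beyond the scatter), the first measured sign that this one position matters in this assay. At this position, then, the hydrogen on the oxygen cannot be swapped for methyl without far more compound being tolerated than with compound 1, which gives 5400 nM. Compound 3 reads > 100000 nM, which is a limit of the assay and not a number, so the true size of the step stays unknown: the limit of > 100000 nM in this assay, at which 1 of the 3 values shown sits.

On these data alone, what stays open is whether the loss of that hydrogen or the added methyl carries the effect. An acetyl group or a longer chain such as ethyl on the same oxygen, or an amine in place of the hydroxy, would speak to how narrow this requirement is.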